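Isopropyl for chloro on the pyridine N-oxide core

The source may hold more compounds than are shown below. What is called first, only, known or untested is meant among the compounds shown, and "the series" means these compounds.

Compound 1 `[O-][n+]1ccc(Cl)c(Oc2ccccc2)c1`: in a functional assay on the whole organism with Mus musculus as the target, in the maximal electroshock model, with a stated time of 30 min (on this read-out lower numbers stand for an effect already at smaller amounts and higher numbers for an effect only at larger amounts of compound), compound 1 gives > 300 mg/kg, which is a limit of the assay and not a number.
Compound 2 `Cc1cc[n+]([O-])cc1Oc1ccc(Cl)cc1`: in this assay compound 2 gives 100 mg/kg.
Compound 3 `Cc1ccc(Oc2c[n+]([O-])ccc2C)cc1`: in this assay compound 3 gives 300 mg/kg.

Compound 1 therefore stands at the edge of what was measured; it shares (the limit of > 300 mg/kg in this assay, at which 1 of the 3 values shown sits), and no number is known for it. Compound 4 `CC(C)c1cc[n+]([O-])cc1Oc1ccccc1` differs from compound 1 in one place: isopropyl in place of chloro on an aromatic carbon. For the measured compounds named here, the only measured step that touches this kind of exchange is a 3.0-fold higher number from compound 2 to compound 3 (0.48 log units; beyond the scatter), where an alkyl group replacing chloro moved the read-out toward the weaker side. That step is modest and the exchange here puts in a larger alkyl group, so no move toward smaller numbers is expected; compound 4 is expected to sit at or beyond the limit again. The step from compound 1 to compound 4 is thus estimated as a number no higher from compound 1 to compound 4 (the limit leaves the size open), and compound 4 is expected to give about 300 mg/kg, within a range from 100 mg/kg to 1000 mg/kg.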

Compound 4, minimum effective dose: 30 mg/kg
Beside the measured number, compound 4's estimate is 10-fold (1.00 log units) above it; measured number below the stated range.
By their numbers in this assay, from the lowest: compound 4; then compound 2; then compound 3.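

Isopropyl in place of chloro at this place, opposite the ring nitrogen, gives an at least 10-fold lower number from compound 1 to compound 4 (1.00 log units; beyond the scatter) in this assay, so chloro is not needed here for an effect on the core of compound 1. Compound 1 has > 300 mg/kg, which is a limit of the assay and not a number. The earlier exchange of chloro for an alkyl group, a 3.0-fold higher number from compound 2 to compound 3 (0.48 log units; beyond the scatter), lay at another place in the molecule and went the other way, although the entering group there was methyl rather than isopropyl.

From the compounds shown here alone, it remains open whether a cyclopropyl group, a tert-butyl group or an amine at this place would match isopropyl in compound 4. The full size of the step stays unknown: the limit of > 300 mg/kg in this assay, at which 1 of the 4 values shown sits.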